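The source may hold more compounds than are shown below. What is called first, only, known or untested is meant among the compounds shown, and "the series" means these compounds.

Among the compounds with values here, compound 1 `CS(=O)(=O)c1cnc(C(=O)CCc2ccc(-c3ccccc3)cc2)o1` carries a methylsulfonyl group on the shared core and gives 1.2 nM in an assay for inhibition of Fatty-acid amide hydrolase 1 (Rattus norvegicus) (on this read-out lower numbers stand for stronger inhibition and higher numbers for weaker inhibition), the lowest of the three numbers so far. Compound 3 `O=C(CCc1ccc(COc2ccccc2)cc1)c1ncc(-c2cccc(-c3nnn[nH]3)n2)o1` gives 21 nM and compound 2 `COC(=O)c1cccc(-c2cnc(C(=O)CCc3ccc(OC4CCN(C(=O)OC(C)(C)C)CC4)cc3)o2)n1` gives 32 nM, each beyond the scatter away from compound 1; both carry an aromatic ring in place of the methylsulfonyl group, though their tails differ too. Compound 4 `O=C(O)c1ccc(-c2cnc(C(=O)CCc3ccc(-c4ccccc4)cc3)o2)nc1` keeps the tail of compound 1 and changes only that position: 5-carboxypyridin-2-yl in place of methylsulfonyl on an aromatic carbon. Since the measured compounds with a ring there, compound 2 at 32 nM and compound 3 at 21 nM, are weaker, a moderate loss beyond the scatter is expected, a 5.0-fold higher number from compound 1 to compound 4 (0.70 log units; beyond the scatter). Compound 4 is estimated at 6 nM, within 1.5 nM to 25 nM.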

Compound 4, inhibition constant: 14 nM
Compound 4: middle estimate off by 2.3-fold (0.37 log units), on the low side; measured number inside the range.
By their numbers in this assay, from the lowest: compound 1; then compounds 4, 3 and 2 (each within the scatter of the next, the first and the last beyond it).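

With the tail of compound 1 held constant, this change at the aromatic carbon next to the ring oxygen can be read on its own: in this assay, 5-carboxypyridin-2-yl in place of methylsulfonyl gives a 12-fold higher number from compound 1 to compound 4 (1.07 log units; beyond the scatter). Compound 2 and compound 3 differ from compound 1 in their tails as well, so neither isolates this position. No measurement here explains the loss. Still open, from the compounds shown here alone, is whether the loss follows the ring itself or its carboxy group; an unsubstituted pyridin-2-yl ring on this tail would separate the two.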